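The compounds below may be only part of what the source reports. "The series", "measured", "known", "first", "only" and "open" are said of these compounds alone.

Compound 1 `O=C(Nc1cccc(OCc2cn(-c3ccccc3)nn2)c1)Nc1ccc(Cl)c(C(F)(F)F)c1` gives 1780 nM in a functional assay on HepG2 cells (Homo sapiens) for inhibition, read by MTT assay, with a stated time of 72 h; a lower number here means a stronger inhibitor, a higher number a weaker inhibitor. Compound 2 `Cc1ccccc1-n1cc(COc2cccc(NC(=O)Nc3ccc(Cl)c(C(F)(F)F)c3)c2)nn1` gives 3440 nM. Compound 3 `O=C(Nc1cccc(OCc2cn(-c3ccccc3Cl)nn2)c1)Nc1ccc(Cl)c(C(F)(F)F)c1` gives 1960 nM.

The three measured numbers lie close together. The step of a 1.1-fold higher number from compound 1 to compound 3 (0.04 log units; within the scatter) and the step of a 1.8-fold lower number from compound 2 to compound 3 (0.24 log units; within the scatter) are both within the scatter, so compound 3 cannot be told apart from either of its neighbours in this assay, and all three compounds are best treated as one level.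

Compound 4 `O=C(Nc1cccc(OCc2cn(-c3cccc(I)c3)nn2)c1)Nc1ccc(Cl)c(C(F)(F)F)c1` has not yet been measured. It differs from compound 3 in one place: 3-iodophenyl in place of 2-chlorophenyl on an aromatic nitrogen. The measured steps that bear on this are the ones that vary the same phenyl ring on the same ring nitrogen: a 1.9-fold higher number from compound 1 to compound 2 (0.29 log units; within the scatter) and a 1.1-fold higher number from compound 1 to compound 3 (0.04 log units; within the scatter), where a methyl or a chloro group entered this ring, and a 1.8-fold lower number from compound 2 to compound 3 (0.24 log units; within the scatter), where chloro replaced methyl. None of them moved the number beyond the scatter. A 3-iodophenyl group has not been tested, so the expectation rests on these three steps alone.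

Compound 4 is therefore expected to give about 1900 nM, within a range of 750 nM to 4800 nM. The change from compound 3 is expected to be a 1.0-fold lower number from compound 3 to compound 4 (0.01 log units; within the scatter), with no shift beyond the scatter.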

Compound 4, half-maximal inhibitory concentration: 4780 nM
Beside the measured number, compound 4's estimate is 2.5-fold (0.40 log units) below it, and the stated range covers the measured number.
By their numbers in this assay, from the lowest: compounds 1, 3, 2 and 4 (each within the scatter of the next, the first and the last beyond it).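

In this assay, among the compounds shown here, the entry of a 3-iodophenyl group on the aromatic nitrogen is the first change at this ring to pass the scatter, with a 2.7-fold higher number from compound 1 to compound 4 (0.43 log units; beyond the scatter) and a 2.4-fold higher number from compound 3 to compound 4 (0.39 log units; beyond the scatter) as modest steps toward a weaker inhibitor. The shift has its limits, for a 1.4-fold higher number from compound 2 to compound 4 (0.14 log units; within the scatter) stays within the scatter, so this change sets compound 4 apart from compound 1 and compound 3 but not from compound 2. Nothing measured here accounts for the shift.

Because the step from 2-chlorophenyl to 3-iodophenyl changes both the halogen and its place on the phenyl ring, the compounds shown leave open which of the two goes with the higher number, and a 3-chlorophenyl or a 2-iodophenyl group would separate them. As far as these compounds go, how an amine or a carboxylic acid on this phenyl ring would read in this assay also remains open.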